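A few compounds are considered here, and "the series" means these few. Any claim that something is new, unique, unknown or untested is made for them only; others in the source may bear on it.

In an ADME assay on PA-1 cells (Homo sapiens) for cytotoxicity, read by MTT assay, with a stated time of 72 h (on this read-out lower numbers stand for stronger inhibition and higher numbers for weaker inhibition), three compounds have been read so far. Compound 1 `COc1cc(C2=C(c3cc(C)c(OC)c(C)c3)C(OC(C)=O)CC2=O)cc(OC)c1OC` gives > 100 ug/mL, a limit of the assay and not a number. Compound 2 `COC(=O)c1cc(C2=C(c3cc(OC)c(OC)c(OC)c3)C(=O)CC2O[SiH2]C(C)(C)C)ccc1OC` gives > 100 ug/mL, likewise a limit. Among the compounds with values here, compound 3 `COc1ccc(C2=C(c3cc(OC)c(OC)c(OC)c3)C(=O)C(O[SiH2]C(C)(C)C)C2)cc1` gives 7 ug/mL, the only true number in the set. Compound 2 therefore stands at the limit of > 100 ug/mL in this assay, at which 2 of the 3 values shown sit.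

Compound 4 `COc1cc(C2=C(c3cc(C)c(OC)c(C)c3)C(O[SiH2]C(C)(C)C)CC2=O)cc(OC)c1OC` has not yet been measured. It carries 4-methoxy-3,5-dimethylphenyl in place of the 4-methoxy-3-(methoxycarbonyl)phenyl of compound 2, on a double-bonded ring carbon: 4-methoxy-3,5-dimethylphenyl in place of 4-methoxy-3-(methoxycarbonyl)phenyl on a double-bonded ring carbon. The entering group also stands on compound 1, whose reading is the limit > 100 ug/mL, so the new group offers no measured sign of gain. Within the data shown here, compound 3, at 7 ug/mL, shows only that a number can be reached in this assay. A modest move toward lower numbers is therefore expected, though compound 4 may also stay at the limit. The expected step is an at least 2.0-fold lower number from compound 2 to compound 4 (0.30 log units; that floor lies within the scatter). For compound 4 the estimated value is 50 ug/mL, with an expected range of 10 ug/mL to 120 ug/mL.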

Compound 4, half-maximal inhibitory concentration: 32 ug/mL
For compound 4 the middle estimate is 1.6-fold (0.19 log units) above the measured one, within the range that was stated.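

In this assay, within the data shown here, 4-methoxy-3,5-dimethylphenyl in place of 4-methoxy-3-(methoxycarbonyl)phenyl on a double-bonded ring carbon gives an at least 3.1-fold lower number from compound 2 to compound 4 (0.49 log units; beyond the scatter), the first sign that a change at this position can bring a reading below the limit. The entering group does not do this by itself, since a group of 5 heavy atoms (4 carbon, 1 silicon; no ring) in place of a group of 3 heavy atoms (2 carbon, 1 oxygen; no ring), on an oxygen on a saturated carbon, gives an at least 3.1-fold lower number from compound 1 to compound 4 (0.49 log units; beyond the scatter). Both steps are floors, each starting from a limit of the assay and not a number: the limit of > 100 ug/mL in this assay, at which 2 of the 4 values shown sit.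

The compounds shown leave open how far either step truly reaches. They also leave open how an amine or a carboxylic acid on that phenyl ring would read, or a hydroxyl on that saturated carbon.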